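Moving the methoxy group: compound 2 to compound 3

A few compounds are considered here, and "the series" means these few. Any claim that something is new, unique, unknown or untested is made for them only; others in the source may bear on it.

Measured so far:
compound 1 `O=S(=O)(NCCCCNCc1ccc(Br)cc1)c1cc(C(F)(F)F)cc(C(F)(F)F)c1`: 2100 nM
compound 2 `COc1cccc(CNCCCNS(=O)(=O)c2cc(C(F)(F)F)cc(C(F)(F)F)c2)c1`: 3400 nM

Among the compounds with values here, in a functional assay on MIA PaCa-2 cells (Homo sapiens) for inhibition, read by MTT assay, with a stated time of 72 h (on this read-out higher numbers stand for weaker inhibition of growth and lower numbers for stronger inhibition of growth), compound 2 holds the higher of the two numbers; the one step known, a 1.6-fold higher number from compound 1 to compound 2 (0.21 log units; within the scatter), stays within the scatter. Compound 3 `COc1ccccc1CNCCCNS(=O)(=O)c1cc(C(F)(F)F)cc(C(F)(F)F)c1` differs from compound 2 by 2-methoxyphenyl in place of 3-methoxyphenyl on a saturated chain carbon bound to an amine nitrogen. Within the data shown here, no measured step bears directly on this change; the only step so far, an exchange of one benzyl group for another, produced no movement beyond the scatter. The step is therefore expected to be small: a 1.1-fold lower number from compound 2 to compound 3 (0.05 log units; within the scatter). The estimate for compound 3 in this assay is 3000 nM, with a range of 1200 nM to 8000 nM.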

Compound 3, concentration for 50% growth inhibition: 3100 nM
Compound 3: middle estimate off by 1.0-fold (0.01 log units), on the low side; measured number inside the range.
By their numbers in this assay, from the lowest: compounds 1, 3 and 2 (each within the scatter of the next).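

In this assay, the methoxy group can be exchanged between 3-methoxyphenyl and 2-methoxyphenyl on a saturated chain carbon bound to an amine nitrogen with a 1.1-fold lower number from compound 2 to compound 3 (0.04 log units; within the scatter), so this isomer change gives no readable difference. The comparison with the bromobenzyl compound, a 1.5-fold higher number from compound 1 to compound 3 (0.17 log units; within the scatter), likewise shows no separation. No measurement available here accounts for this result.

Still open, as far as these compounds go, is whether 4-methoxyphenyl, a pyridine ring or a carboxylic acid on the ring would move the number beyond the scatter. The effect of chain length alone also remains unresolved.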